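The source may hold more compounds than are shown below. What is called first, only, known or untested is meant among the compounds shown, and "the series" means these compounds.

The measured compounds in an ADME assay on HEK293 cells (Homo sapiens) for cytotoxicity, read by resazurin assay, with a stated time of 48 h; on this read-out lower numbers stand for higher toxicity in this test and higher numbers for lower toxicity in this test:

Compound 1 `O=S(=O)(Nc1ccc(-c2nc3ccccc3o2)cc1)c1ccc(Cl)c(C(F)(F)F)c1` gives 69000 nM in this assay.
Compound 2 `CS(=O)(=O)Nc1ccc(-c2nc3ccccc3o2)cc1` reaches only the limit > 100000 nM in this assay, so no number is known for it.
Compound 3 `O=S(=O)(Nc1ccc(-c2nc3ccccc3o2)cc1)c1ccc(Cl)cc1` likewise reaches only the limit > 100000 nM in this assay.

Compound 3 therefore stands at the edge of what this assay can report; it shares this with compound 2, as the limit of > 100000 nM in this assay, at which 2 of the 3 values shown sit, shows, and only compound 1 gives a number at all.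

Compound 4 `O=[N+]([O-])c1cc(S(=O)(=O)Nc2ccc(-c3nc4ccccc4o3)cc2)ccc1Cl` differs from compound 3 in one place: nitro in place of hydrogen on an aromatic carbon.

Within the data shown here, two measured steps touch this part of the molecule. The step of an at least 1.4-fold higher number from compound 1 to compound 3 (0.16 log units; that floor lies within the scatter) concerns the same ring and shows a small change whose floor lies within the scatter. The step that the two limits leave unreadable from compound 2 to compound 3 cannot be read because both values are limits. Neither step reports a nitro group, so the expectation for compound 4 rests on the observation that all three compounds sit at or near the limit of this assay.

Compound 4 is therefore expected to show a step of about an at least 1.2-fold lower number from compound 3 to compound 4 (0.09 log units; that floor lies within the scatter), that is, no change beyond the scatter, and its estimated value is 80000 nM, with a range from 30000 nM to 200000 nM.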

Compound 4, half-maximal cytotoxic concentration: 85000 nM
Compound 4: middle estimate off by 1.1-fold (0.03 log units), on the low side, and the stated range covers the measured number.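

In this assay, nitro on this ring carbon, ortho to a chloro group, gives a number where hydrogen gave only a limit, and the step is an at least 1.1-fold lower number from compound 3 to compound 4 (0.07 log units; that floor lies within the scatter), so nitro brings no change that can be told from the scatter. Nitro and trifluoromethyl at this same place also cannot be told apart, with a 1.2-fold higher number from compound 1 to compound 4 (0.09 log units; within the scatter), which gives this position a second group with no clear effect on the read-out. The value of compound 3 remains a limit and not a number, and it is not alone in that: the limit of > 100000 nM in this assay, at which 2 of the 4 values shown sit.

Going by these compounds, whether an amine or a carboxylic acid at this place would read the same stays open. Every compound shown with a group here also carries the chloro group, so how nitro reads without chloro is open too.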